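A few compounds are considered here, and "the series" means these few. Any claim that something is new, unique, unknown or untested is made for them only; others in the source may bear on it.

Within the data shown here, compound 2 `CCCCNS(=O)(=O)c1ccc(Nc2ncc3c(n2)N(C2CCCC2)[C@H](CC)C(=O)N3C)cc1` stands with the highest number of the two measured so far in an assay for inhibition of serine/threonine-protein kinase PLK2 (Homo sapiens), read by FRET and Z'-LYTE, with a stated time of 1 h; a higher number here means a weaker inhibitor, a lower number a stronger inhibitor: in this assay compound 2 gives 19.9 nM. Its nearest neighbour is compound 1 `CC[C@@H]1C(=O)N(C)c2cnc(Nc3ccc(S(=O)(=O)NC)cc3)nc2N1C1CCCC1`, which in this assay gives 3.4 nM. Among the measured compounds shown here, the only measured step joining the two, a 5.9-fold higher number from compound 1 to compound 2 (0.77 log units; beyond the scatter), shows that adding a propyl to the methyl on the sulfonamide nitrogen weakened inhibition by a modest but real margin.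

Compound 3 `CCCNS(=O)(=O)c1ccc(Nc2ncc3c(n2)N(C2CCCC2)[C@H](CC)C(=O)N3C)cc1` sits between these two. It differs from compound 2 by hydrogen in place of methyl on a saturated chain carbon, three bonds along the chain from a sulfonamide nitrogen; read one bond further out, the change is butyl to propyl. The step from compound 1 to compound 2 bears on this because a 5.9-fold higher number from compound 1 to compound 2 (0.77 log units; beyond the scatter) covers the whole lengthening from methyl to butyl, and compound 3 undoes only part of it. Taking that step as the only guide, compound 3 is expected to give a somewhat lower number than compound 2, and the expected step is a 1.7-fold lower number from compound 2 to compound 3 (0.22 log units; within the scatter). The estimated value for compound 3 in this assay is 12 nM, with a likely range from 5 nM to 30 nM.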

Compound 3, half-maximal inhibitory concentration: 17.8 nM
Compound 3: middle estimate off by 1.5-fold (0.17 log units), on the low side; the measured number falls inside the stated range.
By their numbers in this assay, from the lowest: compound 1; then compounds 3 and 2 (each within the scatter of the next).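

Going from butyl to propyl at this place, three bonds along the chain from a sulfonamide nitrogen, gives a 1.1-fold lower number from compound 2 to compound 3 (0.05 log units; within the scatter) in this assay, so the end methyl of the butyl chain makes no readable difference here. The step from the methyl sulfonamide of compound 1 tells a different story: a 5.2-fold higher number from compound 1 to compound 3 (0.72 log units; beyond the scatter) is already beyond the scatter and of much the same size as the step from compound 1 to the butyl compound. Read together, these steps show that the loss of inhibition is already present once the chain has reached propyl, and that the further carbon of butyl adds nothing that can be told apart, so the effect of chain length is not a steady climb with each added carbon.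

The compounds shown leave open where the loss sets in, since an ethyl on the sulfonamide nitrogen would fall in the untested part of the series, and whether a longer chain such as pentyl, or a propyl chain ending in an amine or a carboxylic acid, would stay level with compound 3. Nothing measured here explains why the numbers behave this way.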